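Halogen swap on the pendant phenyl of a trimethoxyphenyl benzimidazole

The compounds below may be only part of what the source reports. "The series", "measured", "known", "first", "only" and "open" are said of these compounds alone.

Of the compounds shown here, three sharing one core have been measured in a functional assay on SGC-7901 cells (Homo sapiens) for antiproliferative activity, read by MTT assay, with a stated time of 72 h; on this read-out lower numbers stand for stronger inhibition and higher numbers for weaker inhibition. Compound 1 `COc1ccccc1-c1ccc2ncn(-c3cc(OC)c(OC)c(OC)c3)c2c1` gives 5050 nM. Compound 3 `COc1cc(-n2cnc3ccc(-c4cc(F)ccc4F)cc32)cc(OC)c1OC` gives 6590 nM, the highest of the two numbers reported, and its nearest neighbour is compound 1, the step of a 1.3-fold higher number from compound 1 to compound 3 (0.12 log units; within the scatter) lying within the scatter. Compound 2 `COc1cc(-n2cnc3ccc(-c4ccccc4Cl)cc32)cc(OC)c1OC` reaches only the limit of this assay, > 10000 nM, a threshold rather than a number (the limit of > 10000 nM in this assay, at which 1 of the 3 values shown sits). From compound 2 to compound 3 the step is an at least 1.5-fold lower number from compound 2 to compound 3 (0.18 log units; that floor lies within the scatter), and from compound 1 to compound 2 it is an at least 1.9-fold higher number from compound 1 to compound 2 (0.29 log units; that floor lies within the scatter); neither of these halogen or methoxy exchanges on the pendant phenyl moved the read-out beyond the scatter.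

Compound 4 `COc1cc(-n2cnc3ccc(-c4ccc(Cl)cc4Cl)cc32)cc(OC)c1OC` continues this series. It differs from compound 3 by 2,4-dichlorophenyl in place of 2,5-difluorophenyl on an aromatic carbon. Within the data shown here, the steps that bear on it are those between compounds 1, 2 and 3, all exchanges of substituents on the same pendant ring, and all small. The account therefore expects no step beyond the scatter in this assay, with a slight lean toward a higher number given that compound 2, the other chloro-bearing analogue, gave > 10000 nM. Compound 4 is estimated at 8000 nM, between 3500 nM and 20000 nM, a step of a 1.2-fold higher number from compound 3 to compound 4 (0.08 log units; within the scatter) from compound 3 that is expected to stay within the scatter.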

Compound 4, half-maximal inhibitory concentration: > 10000 nM
Compound 4: no number, only a limit; the forecaster's own chance of this, stated with the estimate: 35%; middle value at least 1.2-fold (0.09 log units) from the limit.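

In this assay compound 4 stops at a limit of the assay and not at a number, and it is the second compound there: the limit of > 10000 nM in this assay, at which 2 of the 4 values shown sit. The 2,4-dichlorophenyl group can therefore be set against the other pendant rings only through floors, an at least 1.5-fold higher number from compound 3 to compound 4 (0.18 log units; that floor lies within the scatter) and an at least 1.9-fold higher number from compound 1 to compound 4 (0.29 log units; that floor lies within the scatter), so even this second chloro-bearing ring shows no step beyond the scatter, and the step from compound 2 to compound 4, chloro in place of hydrogen, cannot be read at all. What compound 4 adds is a regularity confined to these four compounds: both chloro-bearing rings, in compound 2 and compound 4, end at the limit, whereas the 2-methoxyphenyl of compound 1 and the 2,5-difluorophenyl of compound 3 give numbers.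

On these data alone, how far compound 2 and compound 4 lie past the limit stays open, and with it whether the second chloro changes anything. Also open is whether a pendant ring carrying an amine, a hydroxyl or a carboxylic acid would give a step beyond the scatter in this assay, since every ring shown carries only chloro, fluoro or methoxy.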